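Tetrazolylacetamides on the pyrazole amine: pyridyl to fluorophenyl

The compounds below may be only part of what the source reports. "The series", "measured", "known", "first", "only" and "open" are said of these compounds alone.

Of the compounds shown here, two have been measured in an assay on HEK293 cells for activation of Kir3.1/Kir3.2 (Homo sapiens), read by thallium flux; a higher number here means that more compound is needed for the effect, a lower number that less compound is needed. Compound 1 `Cc1cc(NC(=O)Cn2nnc(-c3ccccc3)n2)n(C2CC2)n1` carries a phenyl on the tetrazole and a cyclopropyl on the pyrazole nitrogen; for compound 1 this assay reports only a limit, > 5000 nM, which is the limit noted in the limit of > 5000 nM in this assay, at which 1 of the 2 values shown sits. Among the measured compounds shown here, compound 2 `Cc1cc(NC(=O)Cn2nnc(-c3ccccn3)n2)n(C2CCCCC2)n1` carries a pyridin-2-yl on the tetrazole and a cyclohexyl on the pyrazole nitrogen; in this assay compound 2 gives 14600 nM, the only number in the set. Compound 3 `Cc1cc(NC(=O)Cn2nnc(-c3ccccc3F)n2)n(C2CCCCC2)n1` keeps the cyclohexyl of compound 2 and differs in one place: 2-fluorophenyl in place of pyridin-2-yl on an aromatic carbon. For the measured compounds named here, no measured step of this kind exists in the set, so the expectation rests on compound 2 alone and the step from compound 2 to compound 3 is expected to stay within the scatter, a 1.2-fold lower number from compound 2 to compound 3 (0.09 log units; within the scatter). Compound 3 is therefore estimated at 12000 nM, within 4000 nM to 40000 nM, with a fair chance that only a limit is reported.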

Compound 3, half-maximal effective concentration: 187 nM
Compound 3: the middle estimate sits 64-fold (1.81 log units) above what was measured, and the stated range ends above it.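

This place on the tetrazole, two ring bonds from the ring atom that bears a large group, proves highly sensitive to the aromatic group it carries: with the cyclohexyl on the pyrazole nitrogen held constant, 2-fluorophenyl in place of pyridin-2-yl gives a 78-fold lower number from compound 2 to compound 3 (1.89 log units; beyond the scatter) in this assay and brings the series well below the other values shown. Compound 1 differs from compound 3 in more than one place, so it adds no reading of this change. No measurement shown gives a cause for this step.

Still open, as far as these compounds go, is whether the step belongs to the added fluorine, the lost ring nitrogen or both, and how a 2-chlorophenyl or 2-methoxyphenyl would read at this place. The separate contribution of the cyclohexyl and the cyclopropyl on the pyrazole nitrogen also remains unresolved.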